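The source may report more compounds than this note shows. Statements on the series, on what has been measured and on what is new or still open speak of the compounds shown alone.

Going by the values given here, in a functional assay on KYSE-410 cells (Homo sapiens) for antiproliferative activity, read by MTT assay, with a stated time of 72 h (a lower number here means a stronger inhibitor, a higher number a weaker inhibitor), compound 1 `O=C(Nc1cccc(F)c1)c1cc(=O)[nH]c2cc(Br)ccc12` gives 7300 nM, the only true number in this small set. Compound 2 `O=C(Nc1cc(F)c(F)c(F)c1)c1cc(=O)[nH]c2cc(Br)ccc12` is reported only as a limit, > 20000 nM. Compound 3 `COc1cccc2c(C(=O)Nc3cc(F)cc(F)c3)cc(=O)[nH]c12` is also reported only as a limit, > 20000 nM. Its real potency in this assay is therefore unknown, and it stands at the limit of > 20000 nM in this assay, at which 2 of the 3 values shown sit.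

Compound 4 `O=C(Nc1cc(F)cc(F)c1)c1cc(=O)[nH]c2c(O)cccc12` differs from compound 3 in one place: hydrogen in place of methyl on an oxygen on an aromatic ring. Hydrogen takes the place of methyl on an oxygen on an aromatic ring, so methoxy becomes hydroxy. Among the compounds with values here, no pair of measured compounds shows this change, so the data give no direct guide to its size or direction.

With compound 1 at 7300 nM, a measurable reading in this assay is possible for this family. Another limit is about as likely for compound 4. A small move towards stronger inhibition is the most that seems reasonable to expect, and even that may not clear the usual scatter. The expected change is an at least 1.2-fold lower number from compound 3 to compound 4 (0.09 log units; that floor lies within the scatter). Compound 4 is estimated at 16000 nM, with an expected range from 6000 nM to 40000 nM.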

Compound 4, half-maximal inhibitory concentration: > 20000 nM
Compound 4: no number, only a limit; the forecaster's own chance of this, stated with the estimate: 55%; middle value at least 1.2-fold (0.09 log units) away from the limit.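

Compound 4, like compound 3, is reported only as a limit in this assay, so the change from methoxy to hydroxy cannot be read as a step. The compounds shown leave open the real potency of compound 3 and compound 4, and whether that change alters it at all, with the set standing as follows: the limit of > 20000 nM in this assay, at which 3 of the 4 values shown sit.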